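This account rests on a few compounds, and the source may have more. Where it says the series, first, only, none or still open, it means among the compounds named here.

Working notes on the series. The shared core is carried by compound 1 `CN(C)CCCOc1c(OCc2ccccc2)cc(O)c2c(=O)cc(-c3ccccc3)oc12`, compound 2 `CCN(CC)CCCOc1c(OCc2ccccc2)cc(O)c2c(=O)cc(-c3ccccc3)oc12` and compound 3 `CN1CCN(CCCOc2c(OCc3ccccc3)cc(O)c3c(=O)cc(-c4ccccc4)oc23)CC1`. In a functional assay on B16 cells (Mus musculus) for cytotoxicity, read by MTT assay, with a stated time of 72 h (a higher number here means a weaker inhibitor, a lower number a stronger inhibitor), compound 1 gives 5420 nM, compound 2 gives 4900 nM and compound 3 gives 3760 nM; the steps of a 1.1-fold lower number from compound 1 to compound 2 (0.04 log units; within the scatter), a 1.4-fold lower number from compound 1 to compound 3 (0.16 log units; within the scatter) and a 1.3-fold lower number from compound 2 to compound 3 (0.12 log units; within the scatter) are all within the scatter, so the three amine heads are not separated by these numbers. Compound 4 `CN(C)CCCCOc1c(OCc2ccccc2)cc(O)c2c(=O)cc(-c3ccccc3)oc12` differs from compound 3 by (dimethylamino)methyl in place of 4-methylpiperazin-1-yl on a saturated chain carbon, three bonds along the chain from an oxygen on an aromatic ring; read one bond further out, this is 3-(4-methylpiperazin-1-yl)propyl to 4-(dimethylamino)butyl. Among the measured compounds shown here, the reverse of the head swap, a 1.4-fold lower number from compound 1 to compound 3 (0.16 log units; within the scatter), was within the scatter; no measured step covers the longer chain. No step beyond the scatter is therefore expected in this assay, a 1.3-fold higher number from compound 3 to compound 4 (0.12 log units; within the scatter), and compound 4 is estimated at 5000 nM, within 2200 nM to 11000 nM.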

Compound 4, half-maximal inhibitory concentration: 3220 nM
Beside the measured number, compound 4's estimate is 1.6-fold (0.19 log units) above it; the measured number falls inside the stated range.
By their numbers in this assay, from the lowest: compounds 4, 3, 2 and 1 (each within the scatter of the next).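

In this assay, the longer 4-(dimethylamino)butyl chain is not separated from any of the three earlier amine heads: a 1.2-fold lower number from compound 3 to compound 4 (0.07 log units; within the scatter), a 1.5-fold lower number from compound 2 to compound 4 (0.18 log units; within the scatter) and a 1.7-fold lower number from compound 1 to compound 4 (0.23 log units; within the scatter). At this place, on a saturated chain carbon, three bonds along the chain from an oxygen on an aromatic ring, the added (dimethylamino)methyl therefore shows no effect beyond the scatter, so chain length is no better resolved here than the amine head. No evidence is available that bears on this result. As far as these compounds go, whether a 2-(dimethylamino)ethyl chain, a 5-(dimethylamino)pentyl chain or a morpholin-4-yl head would step beyond the scatter remains open.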